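A few compounds are considered here, and "the series" means these few. Any claim that something is new, unique, unknown or untested is made for them only; others in the source may bear on it.

Compound 1 `O=C(O)c1csc([C@H]2CC[C@@H]3[C@@H](/C=C/COc4ccccc4)[C@H](O)C[C@@H]3O2)n1` in a functional assay on Chem1 cells for agonist activity at prostaglandin F2-alpha receptor (Homo sapiens), read by fluorescence and calcium flux (on this read-out lower numbers stand for an effect already at smaller amounts and higher numbers for an effect only at larger amounts of compound), reaches only the limit > 10000 nM. Compound 2 `O=C(O)c1csc([C@H]2CC[C@@H]3[C@@H](COc4ccccc4)[C@H](O)C[C@@H]3O2)n1` likewise reaches only the limit > 10000 nM in this assay. Compound 3 `O=C(O)c1csc([C@H]2CC[C@@H]3[C@@H](/C=C/CCOc4ccccc4)[C@H](O)C[C@@H]3O2)n1` gives 380 nM in this assay.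

Compound 2 thus stands at the limit of > 10000 nM in this assay, at which 2 of the 3 values shown sit, so no number is known for it. Compound 4 `O=C(O)c1csc([C@H]2CC[C@@H]3[C@@H](CCOc4ccccc4)[C@H](O)C[C@@H]3O2)n1` differs from compound 2 by phenoxymethyl in place of phenoxy on a saturated chain carbon bound to a saturated ring carbon. For the measured compounds named here, the one measured step with this same exchange, an at least 26-fold lower number from compound 1 to compound 3 (1.42 log units; beyond the scatter), carried the number from a limit down to a measured value. The step to compound 4 is therefore expected to be of that sort, a lowering from the limit, an at least 6.6-fold lower number from compound 2 to compound 4 (0.82 log units; beyond the scatter). As far as these compounds go, its size stays open, as compound 2 supplies only a limit to start from. Compound 4 is expected to give about 1500 nM, between 300 nM and 10000 nM, in this assay.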

Compound 4, half-maximal effective concentration: > 10000 nM
Compound 4 ended at the assay's limit (the forecaster's own chance of this, stated with the estimate: 30%); middle value at least 6.6-fold (0.82 log units) away from the limit.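

Compound 2 and compound 4 both stop at a limit rather than a number, so no step between them can be read: the limit of > 10000 nM in this assay, at which 3 of the 4 values shown sit.

The compounds shown leave open what the true values of compound 2 and compound 4 are, and whether phenoxymethyl in place of phenoxy changes anything here.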